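The source may hold more compounds than are shown below. What is called first, only, known or untested is meant among the compounds shown, and "the series" means these compounds.

Compound 1 `CC(C)C[C@H](N)CN(C(=O)C(C)Cc1ccccc1)c1ccc(-c2ccccc2)cc1`: 1.2 nM
Compound 2 `N[C@@H](CC1CCCCC1)CN(C(=O)[C@@H]1C[C@H]1c1ccccc1)c1ccc(-c2ccccc2)cc1`: 1.7 nM
Compound 3 `CO[C@H](C)[C@H](N)CN(C(=O)[C@@H]1C[C@H]1c1ccccc1)c1ccc(-c2ccccc2)cc1`: 0.68 nM

The three measured compounds share a core and differ only in the group carried by the saturated chain carbon bound to the amine nitrogen. In a functional assay for agonist activity at G protein-coupled receptor 88 (Homo sapiens), read by HTRF and cAMP accumulation (on this read-out lower numbers stand for an effect already at smaller amounts and higher numbers for an effect only at larger amounts of compound), compound 3 gives 0.68 nM, the lowest of the three numbers; its gap to compound 1 lies within the scatter, whereas the step of a 2.5-fold lower number from compound 2 to compound 3 (0.40 log units; beyond the scatter) lies beyond it and is modest.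

Compound 4 `O=C([C@@H]1C[C@H]1c1ccccc1)N(CCNCC1CCCC1)c1ccc(-c2ccccc2)cc1` has not yet been measured. It differs from compound 3 in one place: ((cyclopentylmethyl)amino)methyl in place of 1-amino-2-methoxypropyl on a saturated chain carbon bound to an amide-type nitrogen. For the measured compounds named here, only one measured step bears on this region, a 2.5-fold lower number from compound 2 to compound 3 (0.40 log units; beyond the scatter), and it exchanged the side group while keeping the amine on the same chain carbon. Going by the values given here, the change to compound 4 goes further, moving the amine one carbon along the chain and replacing it with a substituted one, so no measured step is a direct precedent. Given that compound 3 gives 0.68 nM and the modest size of a 2.5-fold lower number from compound 2 to compound 3 (0.40 log units; beyond the scatter), compound 4 is expected to show a somewhat higher number. Compound 4 is estimated at 5 nM in this assay, with a range from 1 nM to 30 nM. This corresponds to an expected step of a 7.4-fold higher number from compound 3 to compound 4 (0.87 log units; beyond the scatter).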

Compound 4, half-maximal effective concentration: 2.5 nM
Compound 4: the middle estimate sits 2.0-fold (0.30 log units) above what was measured; low and high end bracket the measured number.
By their numbers in this assay, from the lowest: compounds 3, 1, 2 and 4 (each within the scatter of the next, the first and the last beyond it).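

The earlier compounds shown here exchanged only the side group on a chain that kept its free amine, whereas compound 4 shows that ((cyclopentylmethyl)amino)methyl, a substituted amine on a saturated chain carbon bound to an amide-type nitrogen, is tolerated in this assay at a modest cost (a 3.7-fold higher number from compound 3 to compound 4 (0.57 log units; beyond the scatter)). Read from 1-amino-2-cyclohexylethyl, the same kind of exchange stays within the scatter (a 1.5-fold higher number from compound 2 to compound 4 (0.17 log units; within the scatter)), so the size of the change depends on the compound it is read from, and the loss from compound 3 cannot be assigned to the new amine alone. Nothing available explains either step.

Compound 4 alters the place of the amine and its substitution at once, so the two cannot be separated: a plain 2-aminoethyl group would be needed to part them. Going by these compounds, it also remains open whether a cyclopentylmethyl group on the amine of compound 3, with the 1-methoxyethyl side group kept, would hold that compound's number.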